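This account rests on a few compounds, and the source may have more. Where it says the series, first, only, none or still open, it means among the compounds named here.

Measured so far in a functional assay on ECa-109 cells for inhibition, with ECa-109 cell line (Homo sapiens) as the target, read by sulforhodamine B assay; a lower number here means a stronger inhibitor, a higher number a weaker inhibitor:
Compound 1, `Cc1ccc(NC2=CC(=O)c3nc4n(c3C2=O)[C@H]2OC[C@@H](O)[C@H]2OC4)cc1C`: 2820 nM.
Compound 2, `O=C1C=C(Nc2cccc(Cl)c2)C(=O)c2c1nc1n2[C@H]2OC[C@@H](O)[C@H]2OC1`: 4690 nM.
Compound 3, `O=C1C=C(N2CCCCC2)C(=O)c2c1nc1n2[C@H]2OC[C@@H](O)[C@H]2OC1`: > 8000 nM, which is a limit of the assay and not a number.

Within the data shown here, compound 3 therefore stands at the floor of what this assay resolved; as the limit of > 8000 nM in this assay, at which 1 of the 3 values shown sits, shows, it is the one of the three values that sits at that limit, while compounds 1 and 2 gave numbers. The step from compound 1 was an at least 2.8-fold higher number from compound 1 to compound 3 (0.45 log units; beyond the scatter), and from compound 2 an at least 1.7-fold higher number from compound 2 to compound 3 (0.23 log units; that floor lies within the scatter); between the two measured numbers themselves a 1.7-fold higher number from compound 1 to compound 2 (0.22 log units; within the scatter).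

Compound 4, `O=C1C=C(N2CCCC2)C(=O)c2c1nc1n2[C@H]2OC[C@@H](O)[C@H]2OC1`, carries the change (pyrrolidin-1-yl in place of piperidin-1-yl on a double-bonded ring carbon). Among the measured compounds shown here, no measured step compares two saturated cyclic amines with each other; the only steps that bear on the new compound are the two just given, which show that the piperidin-1-yl compound is in each case at least as weak as compounds 1 and 2, and they say nothing about the size of the saturated ring. A step in this assay of no size beyond the scatter is therefore expected, in neither direction, most likely again reported as a limit. For compound 4 the estimate is 10000 nM, with a range of 5000 nM to 30000 nM. The expected step is thus a step that the limit leaves unreadable from compound 3 to compound 4, essentially none.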

Compound 4, half-maximal inhibitory concentration: > 16000 nM
Compound 4 was reported as a limit; the forecaster's own chance of this, stated with the estimate: 70%; at least 1.6-fold (0.20 log units) between middle value and limit.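

In this assay, compound 4 is reported as a limit and not a number: the limit of > 16000 nM in this assay, at which 1 of the 4 values shown sits.

With pyrrolidin-1-yl on this double-bonded ring carbon, the loss against the two aromatic amines can now be read on both sides, as an at least 3.4-fold higher number from compound 2 to compound 4 (0.53 log units; beyond the scatter) and as an at least 5.6-fold higher number from compound 1 to compound 4 (0.75 log units; beyond the scatter); the floor against compound 2 now lies beyond the scatter, whereas the piperidin-1-yl comparison gave only an at least 1.7-fold higher number from compound 2 to compound 3 (0.23 log units; that floor lies within the scatter). The step between the two saturated cyclic amines, compound 3 and compound 4, cannot be read, so these notes place neither the five-membered nor the six-membered ring ahead of the other.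

Still open, as far as these compounds go, is whether the weaker readings of compound 3 and compound 4 go with the loss of the amine hydrogen, the loss of the phenyl ring, or both; a benzylamino group and an N-methyl-N-phenylamino group on the same carbon would separate these. Also open, from the compounds shown here alone, is whether a saturated ring with a second hetero atom, such as morpholin-4-yl, or an open-chain diethylamino group would give a number in this assay rather than a limit.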